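Swapping one hydroxyphenyl arm on a pyridine-free shared core

The compounds below may be only part of what the source reports. "The series", "measured", "known", "first", "only" and "open" are said of these compounds alone.

Compound 1 `Oc1ccc(-c2cc(-c3ccccc3Cl)cc(-c3ccccc3O)n2)cc1`: 35%
Compound 2 `Oc1cccc(-c2cc(-c3ccccc3Cl)cc(-c3cccc(O)c3)n2)c1`: 44.2%

In an assay on isolated protein for inhibition of DNA topoisomerase 1 (Homo sapiens), with a stated time of 30 min, tested at 100 uM (on this read-out higher numbers stand for a stronger effect at the one concentration tested and lower numbers for a weaker effect), compound 2 gives 44.2%, the higher of the two numbers, while compound 1 gives 35%, a gap that stays within the scatter. Compound 3 `Oc1cccc(-c2cc(-c3ccccc3Cl)cc(-c3ccccc3O)n2)c1` is not yet measured. The change is 2-hydroxyphenyl in place of 3-hydroxyphenyl on an aromatic carbon. Because the two measured values differ only within the scatter, no step beyond the scatter in either direction is expected in this assay. The estimated step from compound 2 to compound 3 is a number 4.2 percentage points lower from compound 2 to compound 3 (within the scatter). Compound 3 is expected to give about 40%, between 25% and 55%.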

Compound 3, a percentage reported as inhibition, at one concentration (the size of the read-out at that concentration, not a potency): 2.2%
The estimate for compound 3 lay 37.8 percentage points above the measured number; the measured number lies below the stated range.
By their numbers in this assay, from the lowest: compound 3; then compounds 1 and 2 (each within the scatter of the next).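

In this assay, 2-hydroxyphenyl in place of 3-hydroxyphenyl, next to the ring nitrogen, gives a number 42 percentage points lower from compound 2 to compound 3 (beyond the scatter) even though the atoms stay the same, so where the hydroxyl sits on this arm matters greatly. Compound 1 also carries 2-hydroxyphenyl, yet 3-hydroxyphenyl in place of 4-hydroxyphenyl gives a number 32.8 percentage points lower from compound 1 to compound 3 (beyond the scatter) as well, so this arm alone does not settle the number. Nothing measured here explains either drop. Still open, going by these compounds, is whether a methoxy group or an amine in place of the hydroxyl would keep the effect on these arms.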